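This account rests on a few compounds, and the source may have more. Where it says the series, first, only, none or still open, it means among the compounds named here.

Compound 3 `COc1ccc(Nc2cc(-c3ccco3)oc(=O)c2)cc1` stands second highest of the three numbers in a functional assay on DU-145 cells (Homo sapiens) for cytotoxicity, read by MTT assay, with a stated time of 72 h (on this read-out lower numbers stand for an effect already at smaller amounts and higher numbers for an effect only at larger amounts of compound), where compound 3 gives 1.95 uM. Compound 1 `CCCCCc1cc(Nc2ccc(OC)cc2)cc(=O)o1` gives 5.94 uM, and compound 2 `COc1ccc(Nc2cc(/C=C/c3ccccc3)oc(=O)c2)cc1` gives 0.11 uM. Compound 4 `COc1ccc(Nc2cc(C3CCCC3)oc(=O)c2)cc1` is not yet measured; it differs from compound 3 by cyclopentyl in place of furan-2-yl on an aromatic carbon. The step of a 3.0-fold lower number from compound 1 to compound 3 (0.48 log units; beyond the scatter) bears most on this change, since there a pentyl chain gave way to the furan-2-yl ring. The steps of a 54-fold lower number from compound 1 to compound 2 (1.73 log units; beyond the scatter) and an 18-fold higher number from compound 2 to compound 3 (1.25 log units; beyond the scatter) show that the group at this position can move the number strongly. Cyclopentyl, a ring of carbon only, is closer in kind to pentyl than to furan-2-yl, so a modestly higher number is expected for compound 4, about a 2.3-fold higher number from compound 3 to compound 4 (0.36 log units; beyond the scatter). Compound 4 is therefore estimated at 4.5 uM, with a range from 1.5 uM to 13 uM.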

Compound 4, concentration for half-maximal effect: 5.42 uM
Beside the measured number, compound 4's estimate is 1.2-fold (0.08 log units) below it; measured number inside the range.
By their numbers in this assay, from the lowest: compound 2; then compound 3; then compounds 4 and 1 (each within the scatter of the next).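

In this assay, cyclopentyl in place of furan-2-yl, a five-membered ring with the same heavy-atom count, gives a 2.8-fold higher number from compound 3 to compound 4 (0.44 log units; beyond the scatter), so ring size alone does not fix the number at this position. Closing the chain into a ring makes no readable difference, with a 1.1-fold lower number from compound 1 to compound 4 (0.04 log units; within the scatter), while a 49-fold higher number from compound 2 to compound 4 (1.69 log units; beyond the scatter) shows that neither carbon-only group comes near 2-phenylethenyl. No measured evidence here explains these differences. Still open, going by these compounds, is where a plain phenyl ring, attached without the two-carbon link, would fall, which would separate the effect of that link from the effect of the phenyl ring itself.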